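Ethyl in Place of Cyclopropyl on the Core Nitrogen

The compounds below may be only part of what the source reports. "The series", "measured", "known", "first", "only" and "open" are said of these compounds alone.

Compound 1 `O=c1c(S(=O)(=O)c2ccc(F)cc2F)cc2cnc(Nc3ccc4[nH]ccc4c3)nc2n1C1CC1` gives the lower of the two numbers recorded in a functional assay on DU-145 cells (Homo sapiens) for inhibition, read by trypan blue exclusion, with a stated time of 72 h; on this read-out higher numbers stand for weaker inhibition and lower numbers for stronger inhibition: in this assay compound 1 gives 500 nM, whereas compound 2 `Cn1c(=O)c(S(=O)(=O)Nc2ccc(F)cc2)cc2cnc(Nc3ccc4[nH]ccc4c3)nc21` gives 5000 nM, a gap that lies beyond the usual scatter. Among the compounds with values here, compound 2 differs from compound 1 in more than one place, so no single step links the two, and the data offer no precedent for a change at the aromatic nitrogen alone.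

Compound 3 `CCn1c(=O)c(S(=O)(=O)c2ccc(F)cc2F)cc2cnc(Nc3ccc4[nH]ccc4c3)nc21` differs from compound 1 in one place: ethyl in place of cyclopropyl on an aromatic nitrogen. With no measured pair to guide this change, the expectation is a step of modest size in this assay, if any, with no strong reason to favour either direction beyond the scatter. On that basis compound 3 is estimated at 600 nM, with a likely range from 250 nM to 1500 nM. This estimate corresponds to an expected step of a 1.2-fold higher number from compound 1 to compound 3 (0.08 log units; within the scatter).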

Compound 3, half-maximal inhibitory concentration: 750 nM
Compound 3: the middle estimate sits 1.3-fold (0.10 log units) below what was measured; the range from low to high includes it.
By their numbers in this assay, from the lowest: compounds 1 and 3 (each within the scatter of the next); then compound 2.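

In this assay, within the data shown here, ethyl in place of cyclopropyl on the aromatic nitrogen gives a 1.5-fold higher number from compound 1 to compound 3 (0.18 log units; within the scatter), the first reading of a change at this position with the rest of the molecule held constant. The three-membered ring is therefore not required at this position for activity in this read-out: the open ethyl chain, with one carbon fewer, cannot be told apart from cyclopropyl here. No other measurement bears on why these two groups read alike.

The compounds shown do not say how far this tolerance extends, for instance to a longer chain such as butyl, to a phenyl ring or to a chain ending in an amine. They also leave open whether ethyl and cyclopropyl would read alike with a different group in place of the (2,4-difluorophenyl)sulfonyl group.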